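Notes on an amine exchange in the shared core series

The compounds below may be only part of what the source reports. "The series", "measured", "known", "first", "only" and "open" are said of these compounds alone.

Measured so far, in an ADME assay on MCF-10A cells (Homo sapiens) for cytotoxicity, read by sulforhodamine B assay, with a stated time of 48 h; a higher number here means a weaker inhibitor of growth, a lower number a stronger inhibitor of growth:
compound 1, `Cc1ccc2nc(/N=C3\C(=O)N(CN4CCCCC4)c4cccc(Br)c43)sc2c1` — 18400 nM
compound 2, `O=C1C(=O)N(CN(c2ccccc2)c2ccccc2)c2cccc(Br)c21` — 85800 nM
compound 3, `CCN(CC)CN1C(=O)/C(=N\c2nc3ccc(C)cc3s2)c2ccccc21` — 20400 nM

Compound 1 holds the lowest of the three numbers in this assay. Its nearest neighbour is compound 3, whose number lies within the usual scatter of compound 1, so the two cannot be put in order. Going by the values given here, compound 2 stands furthest away, with a number beyond the scatter above compound 1; no single-point step between any two of these measured compounds is available, so the gap is stated only as the two values show it.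

The next compound, compound 4, is `Cc1ccc2nc(/N=C3\C(=O)N(CN(C)C)c4cccc(Br)c43)sc2c1` and is still to be measured in this assay. Relative to compound 1 its structure differs as follows:

dimethylamino in place of piperidin-1-yl on a saturated chain carbon bound to an amide-type nitrogen in a ring

Both groups carry one hydrogen-bond acceptor and no donor, and the change sits on the saturated chain carbon bound to the amide-type nitrogen in a ring, away from the rest of the shared core. Among the compounds with values here, there is no measured pair that isolates this exchange, so the expectation rests on its small size alone. The step of a 1.1-fold higher number from compound 1 to compound 4 (0.04 log units; within the scatter) is expected to stay within the scatter, with no clear direction. Compound 4 is accordingly estimated at 20000 nM, with a range from 9000 nM to 45000 nM.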

Compound 4, concentration for 50% growth inhibition: 21800 nM
Compound 4: the middle estimate sits 1.1-fold (0.04 log units) below what was measured; measured number inside the range.
By their numbers in this assay, from the lowest: compounds 1, 3 and 4 (each within the scatter of the next); then compound 2.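

Going by these compounds alone, the first measured pair at this position in this assay gives a 1.2-fold higher number from compound 1 to compound 4 (0.07 log units; within the scatter) and lies within the scatter, so compound 1 and compound 4 cannot be put in order. The exchange removes the six-membered non-aromatic ring and goes from 6 heavy atoms to 3 in the group, with the count of hydrogen-bond acceptors and donors unchanged, and in this one pair that difference leaves no readable mark on the number; the ring is thus not required for a number of this size on this core. No supporting measurement is at hand that would explain why the two groups read alike.

From the compounds shown here alone, a single pair with two small amines does not show how much room this position has, and whether morpholin-4-yl, piperazin-1-yl or a primary amine would also stay within the scatter of compound 1 remains open. Equally open, going by these compounds, is whether a longer chain in place of the saturated chain carbon, bound to the same amide-type nitrogen in a ring, would keep the number where compound 1 and compound 4 stand.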